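Swapping a tetrazole for a carboxylic acid on a quinoline core

The source may hold more compounds than are shown below. What is called first, only, known or untested is meant among the compounds shown, and "the series" means these compounds.

Compound 1 `c1cc2ncc(-c3nn[nH]n3)cc2cc1OC1CCCCC1` is tested in a functional assay on the whole organism (strain Sprague-Dawley) for inhibition, with Rattus norvegicus as the target (a lower number here means that less compound is needed, a higher number that more compound is needed for the effect), where compound 1 gives 5 mg/kg. Compound 2 `O=C(O)c1cnc2ccc(OC3CCCCC3)cc2c1` carries the change (carboxy in place of 2H-tetrazol-5-yl on an aromatic carbon). For compound 2 the result in this assay is a limit, > 25 mg/kg, so only a limit and no number is known there. The measured step is an at least 5.0-fold higher number from compound 1 to compound 2 (0.69 log units; beyond the scatter), which rests on (the limit of > 25 mg/kg in this assay, at which 1 of the 3 values shown sits).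

Compound 3 `COc1ccc(OC)c2ncc(-c3nn[nH]n3)cc12` differs from compound 1 in its core, and the difference between the two cores is not broken down here. In this assay compound 3 gives 5 mg/kg, level with compound 1 at the digits shown, within the usual scatter. Compound 4 `COc1ccc(OC)c2ncc(C(=O)O)cc12` is not yet measured; it carries the same change as the earlier pair, (carboxy in place of 2H-tetrazol-5-yl on an aromatic carbon), at a place described in the same words.

Since the same change on compound 1 produced an at least 5.0-fold higher number from compound 1 to compound 2 (0.69 log units; beyond the scatter), a step of like size is expected from compound 3 to compound 4, a 6.0-fold higher number from compound 3 to compound 4 (0.78 log units; beyond the scatter). Compound 4 is therefore estimated at 30 mg/kg, and a limit rather than a number is the likelier outcome.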

Compound 4, minimum effective dose: > 25 mg/kg
Compound 4 was reported as a limit; the forecaster's own chance of this, stated with the estimate: 70%; the middle value does not contradict the limit.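

In this assay, compound 4 gives > 25 mg/kg, which is a limit of the assay and not a number. Even so, the change points the same way on both cores, since carboxy in place of 2H-tetrazol-5-yl gives an at least 5.0-fold higher number from compound 3 to compound 4 (0.69 log units; beyond the scatter), so more compound is needed in this pair just as in the earlier one: the same change on two cores in this assay, an at least 5.0-fold higher number (0.69 log units; beyond the scatter) from compound 1 to compound 2 and an at least 5.0-fold higher number (0.69 log units; beyond the scatter) from compound 3 to compound 4; the limit leaves it open whether they differ. On these data alone, the true size of each step stays unknown, so this series shows that the direction carries over from one core to the other, but not that the size does: the limit of > 25 mg/kg in this assay, at which 2 of the 4 values shown sit.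

The compounds shown leave open how other groups would behave on this aromatic carbon, for example an amide or a sulfonamide in place of the 2H-tetrazol-5-yl group. They also leave open whether the same step would appear on a core that carries an amine or a longer chain.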